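Swapping trifluoromethyl for cyano on a potent scaffold

The source may report more compounds than this note shows. Statements on the series, on what has been measured and on what is new or still open speak of the compounds shown alone.

compound 1 `COc1ccc(-c2cccc(NC(=O)CCc3cccc4c3B(O)OC4)c2)cc1` – 48 nM
compound 2 `COc1cc(OC)cc(-c2cccc(NC(=O)CCc3cccc4c3B(O)OC4)c2)c1` – 44 nM
compound 3 `O=C(CCc1cccc2c1B(O)OC2)Nc1cccc(-c2cccc(C(F)(F)F)c2)c1` – 390 nM

All three values come from a functional assay on SK-OV-3 cells (Homo sapiens) for antiproliferative activity, read by MTT assay, with a stated time of 72 h; on this read-out lower numbers stand for stronger inhibition and higher numbers for weaker inhibition. Compound 3 has the highest number of the set, so it is the weakest of the three, while compound 1 and compound 2 lie within the scatter of each other, as a 1.1-fold lower number from compound 1 to compound 2 (0.04 log units; within the scatter) shows.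

The next compound is compound 4 `N#Cc1cccc(-c2cccc(NC(=O)CCc3cccc4c3B(O)OC4)c2)c1`, which carries cyano in place of trifluoromethyl on an aromatic carbon.

Going by the values given here, no measured compound carries cyano, so no step speaks to this change directly. The nearest evidence comes from changes at the same place: an 8.1-fold higher number from compound 1 to compound 3 (0.91 log units; beyond the scatter) and an 8.9-fold higher number from compound 2 to compound 3 (0.95 log units; beyond the scatter). Both are modest steps, and both leave compound 3 with the higher number. Among the compounds with values here, with only three compounds this is thin support, but it suggests that replacing the 3-(trifluoromethyl)phenyl group is more likely to lower the number in this assay than to raise it, probably by less than those steps. The expected change is a 2.6-fold lower number from compound 3 to compound 4 (0.41 log units; beyond the scatter). For compound 4 the estimated value is 150 nM, with an expected range from 50 nM to 450 nM.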

Compound 4, half-maximal inhibitory concentration: 120 nM
The estimate for compound 4 lay 1.3-fold (0.10 log units) above the measured number, within the range that was stated.
By their numbers in this assay, from the lowest: compounds 2 and 1 (each within the scatter of the next); then compound 4; then compound 3.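

In this assay, going by these compounds alone, the change from trifluoromethyl to cyano on this aromatic carbon gives a 3.3-fold lower number from compound 3 to compound 4 (0.51 log units; beyond the scatter) and shows for the first time that a direct swap of this one group, with the rest of the molecule unchanged, moves the number beyond the scatter. Within the data shown here, the 3-cyanophenyl group does not close the whole gap to the methoxy-bearing compounds, since the steps are a 2.7-fold higher number from compound 2 to compound 4 (0.44 log units; beyond the scatter) and a 2.5-fold higher number from compound 1 to compound 4 (0.40 log units; beyond the scatter) and compound 4 therefore settles between them and compound 3, giving this position an intermediate level that the earlier compounds did not reveal. Nothing measured here accounts for these differences in the antiproliferative read-out.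

Going by these compounds, it remains open whether other groups on the same carbon, such as a chlorine atom, an amine or a carboxylic acid, would land nearer compound 3 or nearer compound 1. On these data alone, it also remains open whether an unsubstituted phenyl ring would match the methoxy-bearing compounds, which would show how much any group on this ring matters at all.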